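The compounds below may be only part of what the source reports. "The series", "measured", "known", "first", "only" and "open" are said of these compounds alone.

Compound 1 `CN1CCCc2c(NC(=O)c3ccc(-c4ccccc4)cc3)cccc21`: in a functional assay for antagonist activity at transient receptor potential cation channel subfamily V member 1 (Homo sapiens), read by FLIPR and calcium flux (on this read-out lower numbers stand for lower potency and higher numbers for higher potency (the scale is a negative logarithm)), compound 1 gives < 6.5, a limit of the assay.
Compound 2 `CN1CCCc2ccc(NC(=O)c3ccc(-c4ccccc4)cc3)cc21`: in this assay compound 2 gives 7.5.
Compound 3 `CN1CCCc2cccc(NC(=O)c3ccc(-c4ccccc4)cc3)c21`: in this assay compound 3 gives < 6.3, a limit of the assay.

Among the compounds with values here, compound 2 thus stands as the only compound of the three with a number in this assay; the other two values are limits. Compound 4 `CN(C)CCN1CCCc2ccc(NC(=O)c3ccc(-c4ccccc4)cc3)cc21` is its untested neighbour, differing by (dimethylamino)methyl in place of hydrogen on a saturated chain carbon bound to a nitrogen on an aromatic ring in a ring. Within the data shown here, no step between two measured compounds touches this change, so the numbers give no calibration for it. The expected step of no change at the digits printed from compound 2 to compound 4 (within the scatter) is therefore taken as none beyond the usual scatter, in either direction. Compound 4 is accordingly estimated at 7.5, with a range from 6.8 to 8.2.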

Compound 4, negative logarithm of the antagonist equilibrium constant: 7.4
For compound 4 the middle estimate is 0.10 log units above the measured one, within the range that was stated.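

In this assay, the change from methyl to 2-(dimethylamino)ethyl gives a number 0.10 log units lower from compound 2 to compound 4 (within the scatter), so this place tolerates the larger group with its amine, with the read-out staying within the scatter. Within the data shown here, the earlier compounds differed only in where the amide sits on the shared core, so this is the first reading of a change at this place. No measurement shown bears on why the two values agree. From the compounds shown here alone, it remains open whether a longer chain, a carboxylic acid or a morpholine at this place would read the same. Going by these compounds, it also remains open whether the same change would hold on the cores of compound 1 and compound 3.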